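Swapping thiomorpholine for morpholine on two pyridine thiosemicarbazides

This account rests on a few compounds, and the source may have more. Where it says the series, first, only, none or still open, it means among the compounds named here.

Compound 1 `Cc1cccc(/C(N)=N/NC(=S)N2CCSCC2)n1` and compound 2 `Cc1cccc(/C(N)=N/NC(=S)N2CCOCC2)n1` share one core and differ in a single place: morpholin-4-yl in place of thiomorpholin-4-yl on a thiocarbonyl carbon. In a functional assay on HeLa cells (Homo sapiens) for cytotoxicity, read by MTT assay, with a stated time of 72 h, tested at 30 uM (a higher number here means more inhibition of growth at the concentration tested, a lower number less inhibition of growth), compound 1 gives 85.3%, and compound 2 gives 86.9%; the measured step is a number 1.6 percentage points higher from compound 1 to compound 2 (within the scatter). Compound 3 `N/C(=N\NC(=S)N1CCSCC1)c1ccc(F)cn1` is built on a different core, and the difference between the two cores is not broken down here. In this assay compound 3 gives 81.7%. Compound 4 `N/C(=N\NC(=S)N1CCOCC1)c1ccc(F)cn1` has not yet been measured; it differs from compound 3 by the same change: morpholin-4-yl in place of thiomorpholin-4-yl on a thiocarbonyl carbon. A step of about the same small size is expected for compound 4, because the earlier step was a number 1.6 percentage points higher from compound 1 to compound 2 (within the scatter). The expected step is a number 1.3 percentage points higher from compound 3 to compound 4 (within the scatter). Compound 4 is estimated at 83%, with a likely range from 72% to 92%.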

Compound 4, percent growth inhibition at one concentration: 84.5%
Estimate against measurement, compound 4: 1.5 percentage points below, and the stated range covers the measured number.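

In this assay, the swap of thiomorpholin-4-yl for morpholin-4-yl on the core of compound 3 gives a number 2.8 percentage points higher from compound 3 to compound 4 (within the scatter), and the two cores agree on this change: the same change on two cores in this assay, a number 1.6 percentage points higher (within the scatter) from compound 1 to compound 2 and a number 2.8 percentage points higher (within the scatter) from compound 3 to compound 4, 1.2 percentage points apart, within the scatter of two such steps

Both steps are small, so on these two cores the swap leaves the reading in this assay practically unchanged. This does not show that the swap would stay as small on any other core, and a single test concentration says nothing about how the compounds would compare at other concentrations.

The compounds shown leave open how a piperidin-1-yl or a 4-methylpiperazin-1-yl ring would read on the same thiocarbonyl carbon of either core.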